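The source may report more compounds than this note shows. Statements on the series, on what has been measured and on what is new or still open speak of the compounds shown alone.

Compound 1, `Fc1ccc2nc(-c3ccccc3)nc(Nc3ccccc3)c2c1`: > 50000 nM
Compound 2, `COc1ccccc1Nc1nc(-c2cccc(F)c2)nc2ccc(F)cc12`: > 50000 nM

In a functional assay on MCF7 cells (Homo sapiens) for cytotoxicity, read by MTT assay, with a stated time of 48 h (on this read-out higher numbers stand for weaker inhibition and lower numbers for stronger inhibition), compound 2 gives > 50000 nM, which is a limit of the assay rather than a measured number. Compound 1 likewise gives only > 50000 nM, a limit. Both values shown sit at the same limit (the limit of > 50000 nM in this assay, at which 2 of the 2 values shown sit), so compound 2 stands level with the other measured compound. Compound 3, `Fc1cccc(-c2nc(Nc3ccc(Cl)cc3)c3cc(F)ccc3n2)c1`, differs from compound 2 by 4-chlorophenyl in place of 2-methoxyphenyl on a nitrogen on an aromatic ring. Among the measured compounds shown here, no measured step covers this change, so nothing here points to a shift in either direction beyond the usual scatter. Compound 3 is expected to give about 60000 nM (range 15000 nM to 250000 nM). The expected step that the limit leaves unreadable from compound 2 to compound 3 is essentially none.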

Compound 3, half-maximal inhibitory concentration: > 50000 nM
Compound 3 gave a limit, no number; the forecaster's own chance of this, stated with the estimate: 75%; the middle value is on the limit's open side.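

No step from compound 2 to compound 3 can be read, since each gives only a limit and not a number: the limit of > 50000 nM in this assay, at which 3 of the 3 values shown sit.

The compounds shown leave open what change to the shared core, if any, would give a measurable number in this assay.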